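Plasma Stability of Two Aminosalicylate Esters and a Third

The source may report more compounds than this note shows. Statements on the series, on what has been measured and on what is new or still open speak of the compounds shown alone.

Compound 1 `Cc1oc(=O)oc1COC(=O)c1ccc(N)cc1O`: 0%
Compound 2 `CC(C)OC(=O)OC(C)OC(=O)c1ccc(N)cc1O`: 0%

In an ADME assay on a cell-free system (plasma, Mus musculus, strain CD-1) for metabolic stability, read by LC-MS, with a stated time of 2 h, tested at 1 ug/mL (a higher number here means that more of the compound is left, a lower number that less of the compound is left), compound 1 gives 0%. In this assay compound 2 gives 0%, level with compound 1 at the digits shown and within the scatter. Compound 3 `CC(OC(=O)c1ccc(N)cc1O)OC(=O)C(C)(C)C` differs from compound 2 by tert-butyl in place of isopropoxy on a carbonyl carbon. Within the data shown here, no step between measured compounds is known here, and both measured compounds leave nothing behind. The step of no change at the digits printed from compound 2 to compound 3 (within the scatter) is therefore expected to be none beyond the scatter. Compound 3 is estimated at 0%, with a range from 0% to 10%.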

Compound 3, percent of the compound remaining: 0%
Compound 3: middle estimate and measured number agree at the digits printed; the measured number falls inside the stated range.
By their numbers in this assay, from the lowest: compounds 1, 2 and 3 (each within the scatter of the next).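

In this assay, putting tert-butyl in place of isopropoxy on a carbonyl carbon gives no change at the digits printed from compound 2 to compound 3 (within the scatter). With compound 3 at 0% as well, this position has now carried two different groups with nothing of the compound left at the stated time, so the read-out cannot separate them. No measured evidence bears on this result.

The compounds shown leave open whether any group on this carbonyl carbon would leave some compound remaining. An amine or a longer chain there could test this, as could an amide in place of the ester on the shared core.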